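Methoxyphenyl in place of nitrophenyl on the unsubstituted core

The source may hold more compounds than are shown below. What is called first, only, known or untested is meant among the compounds shown, and "the series" means these compounds.

Measured so far:
compound 1 `O=C1C(O)=C(C(c2cccc([N+](=O)[O-])c2)c2c[nH]c3ccccc23)C(=O)c2ccccc21`, 36200 nM
compound 2 `O=C1C(O)=C(C(c2ccc([N+](=O)[O-])cc2)c2c(-c3ccccc3)[nH]c3ccccc23)C(=O)c2ccccc21`, 5080 nM
compound 3 `O=C1C(O)=C(C(c2cccc([N+](=O)[O-])c2)c2c(-c3ccccc3)[nH]c3ccccc23)C(=O)c2ccccc21`, 5830 nM

In a functional assay on ECa-109 cells (Homo sapiens) for cytotoxicity, read by MTT assay, with a stated time of 48 h (on this read-out higher numbers stand for weaker inhibition and lower numbers for stronger inhibition), compound 1 stands highest of the three numbers. For the measured compounds named here, its only measured neighbour step, a 6.2-fold lower number from compound 1 to compound 3 (0.79 log units; beyond the scatter), concerns the core and not the aryl group. Compound 4 `COc1ccccc1C(C1=C(O)C(=O)c2ccccc2C1=O)c1c[nH]c2ccccc12` differs from compound 1 as follows: 2-methoxyphenyl in place of 3-nitrophenyl on a saturated chain carbon bound to an aromatic carbon and a double-bonded ring carbon. Going by the values given here, no measured step exchanges the nitrophenyl for a different aryl group; the one step at this position, a 1.1-fold higher number from compound 2 to compound 3 (0.06 log units; within the scatter), stayed within the scatter. Nothing measured therefore points to a step beyond the scatter in this assay, and the range is kept wide. Compound 4 is expected at 30000 nM, between 8000 nM and 100000 nM. The expected step is a 1.2-fold lower number from compound 1 to compound 4 (0.08 log units; within the scatter).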

Compound 4, half-maximal inhibitory concentration: > 200000 nM
Compound 4: only a limit was reported (the forecaster's own chance of this, stated with the estimate: 10%); at least 6.6-fold (0.82 log units) between middle value and limit.
By their numbers in this assay, from the lowest: compounds 2 and 3 (each within the scatter of the next); then compound 1. At a limit, above all of these: compound 4.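

On the core of compound 1, the aryl group on the saturated chain carbon clearly matters: in this assay, 2-methoxyphenyl in place of 3-nitrophenyl gives an at least 5.5-fold higher number from compound 1 to compound 4 (0.74 log units; beyond the scatter). For the compounds shown here, the only earlier step at this position, a 1.1-fold higher number from compound 2 to compound 3 (0.06 log units; within the scatter), exchanged one nitrophenyl for another and stayed within the scatter. For compound 4 the value is a limit and not a number: the limit of > 200000 nM in this assay, at which 1 of the 4 values shown sits.

Open, on these data alone, is whether 3-methoxyphenyl or 4-methoxyphenyl would behave like 2-methoxyphenyl. Also open, as far as these compounds go, is how 2-methoxyphenyl or an aminophenyl group would read on the core of compound 3.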